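Moving the methoxymethoxy group: 2-(methoxymethoxy)phenyl to 3-(methoxymethoxy)phenyl

This account rests on a few compounds, and the source may have more. Where it says the series, first, only, none or still open, it means among the compounds named here.

In a functional assay on HT-29 cells (Homo sapiens) for inhibition, read by MTT assay, with a stated time of 3 days (on this read-out lower numbers stand for stronger inhibition and higher numbers for weaker inhibition), compound 1 `COc1ccccc1/C=C/CCCOc1cc(/C=C\c2cc(OC)c(OC)c(OC)c2)ccc1OC` gives 86000 nM and compound 2 `COCOc1ccccc1/C=C/CCCOc1cc(/C=C\c2cc(OC)c(OC)c(OC)c2)ccc1OC` gives 9600 nM, the lower of the two numbers. Compound 3 `COCOc1cccc(/C=C/CCCOc2cc(/C=C\c3cc(OC)c(OC)c(OC)c3)ccc2OC)c1` has the same atoms as compound 2, joined differently: 3-(methoxymethoxy)phenyl stands in place of 2-(methoxymethoxy)phenyl on a double-bonded chain carbon bound to a double-bonded chain carbon (3-(methoxymethoxy)phenyl in place of 2-(methoxymethoxy)phenyl on a double-bonded chain carbon bound to a double-bonded chain carbon). Going by the values given here, no measured pair shows such a shift. Among the compounds with values here, the only measured step, a 9.0-fold lower number from compound 1 to compound 2 (0.95 log units; beyond the scatter), involves a different change, so it bears on this one only indirectly: altering this end of the molecule has moved the number in this assay beyond the scatter. It gives no direction, so the best expectation stays close to compound 2, with wide uncertainty. The expected step is a 1.3-fold higher number from compound 2 to compound 3 (0.10 log units; within the scatter). For compound 3 the estimate is 12000 nM, with an expected range of 3000 nM to 45000 nM.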

Compound 3, half-maximal inhibitory concentration: 59000 nM
For compound 3 the middle estimate is 4.9-fold (0.69 log units) below the measured one; the whole stated range lies below it.
By their numbers in this assay, from the lowest: compound 2; then compounds 3 and 1 (each within the scatter of the next).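

In this assay, where the methoxymethoxy group sits on the phenyl ring matters, not only whether it is present: with the atoms unchanged, 3-(methoxymethoxy)phenyl in place of 2-(methoxymethoxy)phenyl gives a 6.1-fold higher number from compound 2 to compound 3 (0.79 log units; beyond the scatter). The drop in the number seen with compound 2 therefore belongs to 2-(methoxymethoxy)phenyl and does not carry over to the other placement; set against the 2-methoxyphenyl of compound 1, 3-(methoxymethoxy)phenyl gives only a 1.5-fold lower number from compound 1 to compound 3 (0.16 log units; within the scatter). Nothing at hand accounts for the difference between the two placements.

The compounds shown leave open whether a hydroxyl or an amine in place of the methoxymethoxy group on this ring would hold the number of compound 2. Going by these compounds alone, they also leave open whether a longer chain than the one in compound 2 would change it.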